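Changing the Aryl Group on a Shared Core

The compounds below may be only part of what the source reports. "The series", "measured", "known", "first", "only" and "open" are said of these compounds alone.

Compound 1 `N#CC1=C(N)Oc2c(c3nc4ccccc4nc3c3ccccc23)C12C(=O)N(Cc1cnnn1-c1ccc(S(N)(=O)=O)cc1)c1ccccc12`: in a functional assay on A549 cells (Homo sapiens) for antiproliferative activity, read by MTT assay, with a stated time of 48 h (on this read-out higher numbers stand for weaker inhibition and lower numbers for stronger inhibition), compound 1 gives > 50000 nM, which is a limit of the assay.
Compound 2 `N#CC1=C(N)Oc2c(N)cc3nc4ccccc4nc3c2C12C(=O)N(Cc1cnnn1-c1ccccc1Br)c1ccccc12`: in this assay compound 2 gives 27400 nM.

Going by the values given here, compound 2 holds the only actual number in this assay; the other entry, for compound 1, is a limit rather than a number (the limit of > 50000 nM in this assay, at which 1 of the 2 values shown sits). Among the compounds with values here, no pair of measured compounds differs in a single place, so no measured step can be read off.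

Compound 3 `COc1ccc(OC)c(-n2nncc2CN2C(=O)C3(C(C#N)=C(N)Oc4c(N)cc5nc6ccccc6nc5c43)c3ccccc32)c1` is compound 2 with one change: 2,5-dimethoxyphenyl in place of 2-bromophenyl on an aromatic nitrogen. Within the data shown here, with no measured step of this kind to lean on, the expected step of a 1.1-fold higher number from compound 2 to compound 3 (0.04 log units; within the scatter) from compound 2 to compound 3 in this assay is small, likely no larger than the usual scatter, in either direction. Compound 3 is therefore estimated at 30000 nM, with a range from 10000 nM to 90000 nM, and a real chance that this assay returns only a limit.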

Compound 3, half-maximal inhibitory concentration: 28100 nM
Estimate against measurement, compound 3: 1.1-fold (0.03 log units) above, within the range that was stated.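

Going by these compounds alone, this is the first measured step at this position, on an aromatic nitrogen of a five-membered aromatic ring: putting 2,5-dimethoxyphenyl in place of 2-bromophenyl gives a 1.0-fold higher number from compound 2 to compound 3 (0.01 log units; within the scatter) in this assay. The two aryl groups therefore cannot be told apart on this read-out, even though the bromine leaves and the entering group brings hydrogen-bond acceptors that the leaving group lacks. Compound 1 remains a limit and not a number, and it differs from compound 2 in more than one place, so no step to it can be read: the limit of > 50000 nM in this assay, at which 1 of the 3 values shown sits.

From the compounds shown here alone, it remains open whether any aryl group here can move the number beyond the scatter, for example a phenyl ring carrying an amine or a carboxylic acid. Whether this flat result would hold on a different core is also unknown.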